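Fluoro to bromo: from compound 3 to compound 4

This account rests on a few compounds, and the source may have more. Where it says the series, first, only, none or still open, it means among the compounds named here.

Measured in a functional assay on HUVEC cells (Homo sapiens) for antiproliferative activity, read by MTT assay, with a stated time of 24 h; on this read-out higher numbers stand for weaker inhibition and lower numbers for stronger inhibition:
- compound 1 `C#CCOc1ccc2c(=O)c(-c3cc(OC)c(OC)cc3OC)coc2c1`: > 10000 nM
- compound 2 `COc1cccc(C(=O)Oc2ccc3c(=O)c(-c4cc(OC)c(OC)cc4OC)coc3c2)c1`: > 10000 nM
- compound 3 `COc1cc(OC)c(-c2coc3cc(OCc4ccc(F)cc4)ccc3c2=O)cc1OC`: > 10000 nM

For the measured compounds named here, each of these three entries is a limit and not a number, so the series so far comes down to the limit of > 10000 nM in this assay, at which 3 of the 3 values shown sit. Going by the values given here, no compound here has a measured potency from which to rank the others, and compound 3 holds only its limit.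

The next change leads to compound 4 `COc1cc(OC)c(-c2coc3cc(OCc4ccc(Br)cc4)ccc3c2=O)cc1OC`, with bromo in place of fluoro on an aromatic carbon, para to a large group: bromo in place of fluoro on an aromatic carbon. Among the compounds with values here, three measured steps touch this part of the series: a step that the two limits leave unreadable from compound 1 to compound 2, a step that the two limits leave unreadable from compound 1 to compound 3 and a step that the two limits leave unreadable from compound 2 to compound 3. None of them has a readable size, and none exchanges one halogen for another. They therefore offer no direction for this change.

With nothing pointing either way, no step beyond the scatter is expected in this assay, and another limit is the likeliest report. The estimated step is a step that the limit leaves unreadable from compound 3 to compound 4. For compound 4 the expected value is 15000 nM, with an estimated range from 7000 nM to 40000 nM.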

Compound 4, half-maximal inhibitory concentration: > 10000 nM
Compound 4: only a limit was reported; the forecaster's own chance of this, stated with the estimate: 85%; the middle value is on the limit's open side.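

In this assay compound 4 gives > 10000 nM, a limit and not a number. No step can be read among compound 1, compound 2, compound 3 and compound 4, because all four stand at the same limit: the limit of > 10000 nM in this assay, at which 4 of the 4 values shown sit.

The compounds shown leave open how these groups on the oxygen of the shared core, fluoro and bromo included, rank in this assay.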